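The source may report more compounds than this note shows. Statements on the series, on what has been measured and on what is new or still open speak of the compounds shown alone.

Measured in a functional assay on SW1573 cells (Homo sapiens) for antiproliferative activity, read by sulforhodamine B assay, with a stated time of 48 h; a lower number here means a stronger inhibitor of growth, a higher number a weaker inhibitor of growth:
- compound 1 `CCCCCCC[C@H]1OC(=O)C[C@H]1OC1CCCCC1`: 36000 nM
- compound 2 `CCCCCCC[C@H]1OC(=O)C[C@H]1OC1C=CCCC1`: 49000 nM

Going by the values given here, compound 2 stands within the scatter of compound 1, the only other compound measured. Compound 3 `C=CCC(C)O[C@@H]1CC(=O)O[C@@H]1CCCCCCC` alters the group on the same oxygen: 1-methylbut-3-en-1-yl in place of cyclohex-2-en-1-yl on an oxygen on a saturated carbon. Among the compounds with values here, one measured step bears on this, cyclohex-2-en-1-yl in place of cyclohexyl at that oxygen: a 1.4-fold higher number from compound 1 to compound 2 (0.13 log units; within the scatter). That step stays within the scatter, but it leaves the ring intact, so it is only a loose guide. No change beyond the scatter is therefore expected in this assay. The estimated change is a 1.1-fold lower number from compound 2 to compound 3 (0.04 log units; within the scatter). For compound 3 the expected value is 45000 nM, with an estimated range from 25000 nM to 85000 nM.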

Compound 3, concentration for total growth inhibition: 83000 nM
Compound 3: the middle estimate sits 1.8-fold (0.27 log units) below what was measured; the range from low to high includes it.
By their numbers in this assay, from the lowest: compounds 1, 2 and 3 (each within the scatter of the next, the first and the last beyond it).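

Going by these compounds alone, replacing the ring on this oxygen with an open chain gives the only step in this assay that passes the scatter: a 2.3-fold higher number from compound 1 to compound 3 (0.36 log units; beyond the scatter), and it is modest. Measured against cyclohex-2-en-1-yl, the same open chain stays inside the scatter, a 1.7-fold higher number from compound 2 to compound 3 (0.23 log units; within the scatter), so the gap appears only against the saturated ring. Nothing available explains this difference between the groups. The compounds shown leave open whether an amine, a carboxylic acid or a saturated open chain on this oxygen would move the number in this assay further.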